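A few compounds are considered here, and "the series" means these few. Any claim that something is new, unique, unknown or untested is made for them only; others in the source may bear on it.

In an ADME assay on Caco-2 cells (Homo sapiens) for permeability, read by LC-MS, in the apical to basolateral direction, with a stated time of 120 min, tested at 20 uM (a lower number here means that the compound crosses the layer more slowly, a higher number that the compound crosses the layer faster), compound 1 (`O=C(O)c1ccc(CCOc2c(F)ccc3nc(C(=O)NCc4ccccc4)[nH]c(=O)c23)cc1`) gives 16 10^-6 cm/s and compound 2 (`O=C(O)c1ccc(CCOc2c(F)ccc3nc(C(=O)NCC4CCCCC4)[nH]c(=O)c23)cc1`) gives 32 10^-6 cm/s. Among the compounds with values here, these are the only two numbers so far, and they lie within the scatter of each other, so compound 2 cannot be told apart from compound 1. Compound 3 (`CCc1cccc(CNC(=O)c2nc3ccc(F)c(OCCc4ccc(C(=O)O)cc4)c3c(=O)[nH]2)c1`) keeps the shared core and differs from compound 2 in one group: 3-ethylphenyl in place of cyclohexyl on a saturated chain carbon bound to an amide-type nitrogen. In short, 3-ethylphenyl stands in place of cyclohexyl on a saturated chain carbon bound to an amide-type nitrogen. Within the data shown here, one measured step bears on this, the exchange of phenyl for cyclohexyl at the same place, a 2.0-fold higher number from compound 1 to compound 2 (0.30 log units; within the scatter). Among the measured compounds shown here, no measured compound carries the ethyl group, so its contribution is unknown. The expected step is a 1.5-fold lower number from compound 2 to compound 3 (0.16 log units; within the scatter), with nothing expected beyond the scatter in this assay. For compound 3 the estimated value is 22 10^-6 cm/s, with an expected range from 9 10^-6 cm/s to 50 10^-6 cm/s.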

Compound 3, apparent permeability in the Caco-2 assay: 44 10^-6 cm/s
Estimate against measurement, compound 3: 2.0-fold (0.30 log units) below; the measured number falls inside the stated range.
By their numbers in the Caco-2 assay, from the lowest: compounds 1, 2 and 3 (each within the scatter of the next, the first and the last beyond it).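

In the Caco-2 assay, the exchange on a saturated chain carbon bound to an amide-type nitrogen gives a 1.4-fold higher number from compound 2 to compound 3 (0.14 log units; within the scatter), so 3-ethylphenyl and cyclohexyl cannot be told apart at this place, while ethyl in place of hydrogen on an aromatic carbon gives a 2.8-fold higher number from compound 1 to compound 3 (0.44 log units; beyond the scatter), the only step shown in this assay that lies beyond the scatter. In a physicochemical assay for solubility, read by nephelometry, in phosphate buffer, measured as kinetic solubility, at pH 6.5 (a lower number here means a less soluble compound, a higher number a more soluble compound), compound 2 gives < 1.6 ug/mL, which is a limit of the assay and not a number: the limit of < 1.6 ug/mL in the physicochemical assay, at which 1 of the 2 values shown sits. In the physicochemical assay compound 3 gives 12.5 ug/mL, which reads as an at least 7.8-fold higher number from compound 2 to compound 3 (0.89 log units; beyond the scatter), so the same exchange that stays within the scatter for crossing the cell layer lies beyond it here.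

On these data alone, whether a methyl group, a methoxy group or an amine on the same aromatic carbon would follow ethyl stays open. So does whether these steps would hold with an ester in place of the carboxylic acid.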